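Swapping a dichlorophenyl amide for a benzyl amide

The source may hold more compounds than are shown below. What is called first, only, known or untested is meant among the compounds shown, and "the series" means these compounds.

Four compounds share one core and differ only in the group carried on the amide-type nitrogen. Compound 1 `O=C(CSc1nnc(-c2ccncc2)s1)NCc1ccccc1Cl` has no number in an ADME assay on HepG2 cells (Homo sapiens) for cytotoxicity, with a stated time of 3 days (on this read-out higher numbers stand for lower toxicity in this test and lower numbers for higher toxicity in this test), and its entry reads "not determined" (no result reported). Compound 2 `O=C(CSc1nnc(-c2ccncc2)s1)NCc1ccc(Cl)cc1` in this assay reached only a limit of the test, > 50000 nM, which is not a measured number. Compound 3 `O=C(CSc1nnc(-c2ccncc2)s1)Nc1ccc(Cl)cc1Cl` likewise stands without a single number in this assay, its entry reading "not determined" (no result reported). Of the three entries shown, one sits at the limit of > 50000 nM in this assay, at which 1 of the 3 values shown sits, and one more is empty. Compound 4 `O=C(CSc1nnc(-c2ccncc2)s1)NCc1ccccc1` has not yet been tested in this assay. The change from compound 3 to compound 4 is benzyl in place of 2,4-dichlorophenyl on an amide-type nitrogen, with benzyl entering where 2,4-dichlorophenyl leaves on the amide-type nitrogen. Going by the values given here, no measured step between two compounds exists here, so no size or direction of a step can be read off. Among the compounds with values here, the only guide is that compound 2 gave a limit > 50000 nM. Compound 4 is therefore expected to sit near or beyond the same limit, estimated at 50000 nM with a range from 20000 nM to 100000 nM.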

Compound 4, half-maximal cytotoxic concentration: 17700 nM
Estimate against measurement, compound 4: 2.8-fold (0.45 log units) above; the measured number lies below the stated range.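

Compound 4 gives this series its first single number, and it shows that the aromatic ring of the benzyl group is a place where one small change counts in this assay: hydrogen in place of chloro on an aromatic carbon brings an at least 2.8-fold lower number from compound 2 to compound 4 (0.45 log units; beyond the scatter), which on this read-out means more toxicity in this test. A benzyl amide on the shared core can therefore register as toxic to these cells within the range of the test. The full size of this step stays unknown because compound 2 stands at a limit and not at a number: the limit of > 50000 nM in this assay, at which 1 of the 4 values shown sits.

Steps involving compound 1 or compound 3 cannot be read, so the swap of 2,4-dichlorophenyl for benzyl stays unsettled. From the compounds shown here alone, it also remains open whether a fluoro or methoxy group on the benzyl ring, or a longer phenethyl chain on the amide-type nitrogen, would shift the number as chloro does.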